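Sulfo for sulfanyl on an ethyl ester

The source may hold more compounds than are shown below. What is called first, only, known or untested is meant among the compounds shown, and "the series" means these compounds.

Compound 1 `COc1cc(-c2nc3ccccc3s2)ccc1OCC(=O)NNC(=O)CN[C@@H](CS(=O)(=O)O)C(=O)O` gives 3690 nM
Compound 2 `CCOC(=O)[C@H](CS)NCC(=O)NNC(=O)COc1ccc(-c2nc3ccccc3s2)cc1OC` gives 3760 nM

Both values come from a functional assay on HepG2 cells (Homo sapiens) for inhibition, read by MTT assay, with a stated time of 3 days (a lower number here means a stronger inhibitor, a higher number a weaker inhibitor), where compound 2 stands within the scatter of compound 1. Compound 3 `CCOC(=O)[C@H](CS(=O)(=O)O)NCC(=O)NNC(=O)COc1ccc(-c2nc3ccccc3s2)cc1OC` keeps the ethoxycarbonyl of compound 2 and differs from it by sulfo in place of sulfanyl on a saturated chain carbon, two bonds along the chain from an amine nitrogen and a carbonyl carbon, sulfo in place of sulfanyl on a saturated chain carbon. Compound 1 also carries the sulfo group. Among the measured compounds shown here, the one measured step that bears on this is a 1.0-fold higher number from compound 1 to compound 2 (0.01 log units; within the scatter), so no step beyond the scatter is expected. The expected step is a 1.0-fold lower number from compound 2 to compound 3 (0.01 log units; within the scatter) in this assay. Compound 3 is estimated at 3700 nM, with an expected range from 1800 nM to 7500 nM.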

Compound 3, half-maximal inhibitory concentration: 3360 nM
For compound 3 the middle estimate is 1.1-fold (0.04 log units) above the measured one; measured number inside the range.
By their numbers in this assay, from the lowest: compounds 3, 1 and 2 (each within the scatter of the next).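

In this assay the step of a 1.1-fold lower number from compound 2 to compound 3 (0.05 log units; within the scatter) for sulfo in place of sulfanyl shows that this change, with the ethoxycarbonyl held fixed, stays within the scatter. The step of a 1.1-fold lower number from compound 1 to compound 3 (0.04 log units; within the scatter) for ethyl in place of hydrogen on an oxygen next to a carbonyl group also stays within the scatter, so the two changes made together in the earlier pair are now each read alone. No evidence is available to explain these results. As far as these compounds go, whether an amine or a carboxylic acid on this saturated chain carbon, or a longer chain carrying the sulfo group, would give a step beyond the scatter remains open.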